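A few compounds are considered here, and "the series" means these few. Any claim that something is new, unique, unknown or untested is made for them only; others in the source may bear on it.

Measured compounds in this series:
compound 1 `Cc1ccc(-c2nn(-c3ccc(Cl)cc3)cc2C(CC(=O)c2ccc(Cl)cc2)C(=O)c2ccc(F)cc2)cc1`: 19.4% in a functional assay on the whole organism (strain Wistar albino) for inhibition, with Rattus norvegicus as the target, read by paw edema, with stated times of 1 h and 3 h, at a dose of 0.32 mmol/kg by the intraperitoneal route; on this read-out higher numbers stand for more inhibition at the one dose given (going by the name of the read-out) and lower numbers for less inhibition
compound 2 `COc1ccc(C(=O)C(CC(=O)c2ccc(Cl)cc2)c2cn(-c3ccc(Cl)cc3)nc2-c2ccc(C)cc2)cc1`: 23.9%
compound 3 `Cc1ccc(-c2nn(-c3ccc(S(N)(=O)=O)cc3)cc2-c2cc(-c3ccc(Cl)cc3)[nH]c2-c2ccc(F)cc2)cc1`: 66.7%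

Within the data shown here, the only counted step among the measured compounds is a number 4.5 percentage points higher from compound 1 to compound 2 (within the scatter), the change being (methoxy in place of fluoro on an aromatic carbon). Compound 3 has the highest number of the three, beyond the scatter from both compound 1 and compound 2; how its core differs from the core of compound 1 is not broken down here.

Compound 4 `COc1ccc(-c2[nH]c(-c3ccc(Cl)cc3)cc2-c2cn(-c3ccc(S(N)(=O)=O)cc3)nc2-c2ccc(C)cc2)cc1` has not yet been measured in this assay. It differs from compound 3 by methoxy in place of fluoro on an aromatic carbon. The place of the change is described in the same words in both pairs, so it is taken as the same change, made here on the core of compound 3 rather than that of compound 1.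

From compound 3 to compound 4 a step of about the earlier size is expected, a number 3.3 percentage points higher from compound 3 to compound 4 (within the scatter), resting on a number 4.5 percentage points higher from compound 1 to compound 2 (within the scatter). Since that earlier step lies within the scatter and comes from a single pair on a different core, the expectation for compound 4 is a number close to compound 3, estimated at 70%, with a range from 55% to 82%.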

Compound 4, a percentage reported as inhibition, in the whole organism at one dose (the size of the read-out at that dose, not a potency): 34.2%
Estimate against measurement, compound 4: 35.8 percentage points above; measured number below the stated range.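

In this assay, methoxy in place of fluoro on an aromatic carbon gives a number 32.5 percentage points lower from compound 3 to compound 4 (beyond the scatter), so on the core of compound 3 the 4-fluorophenyl to 4-methoxyphenyl change has a large cost that the core of compound 1 gave no sign of. The step therefore does not carry over between these two cores: the same change on two cores in this assay, a number 4.5 percentage points higher (within the scatter) from compound 1 to compound 2 and a number 32.5 percentage points lower (beyond the scatter) from compound 3 to compound 4, 37 percentage points apart, beyond the scatter of two such steps
This comparison rests on one pair per core and does not show which structural difference between the cores separates the two outcomes, nor how the change would behave on any third core.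

Going by these compounds, it remains open whether the loss on the core of compound 3 is specific to methoxy or would also follow from a hydroxy group, an amine or a longer alkoxy chain at the same place on that ring. The compounds shown also leave open whether a plain hydrogen there, or a carboxylic acid in place of the sulfonamide, would keep the number of compound 3.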